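Swapping the aryl group on a thiourea nitrogen

The source may report more compounds than this note shows. Statements on the series, on what has been measured and on what is new or still open speak of the compounds shown alone.

Of the compounds shown here, two of a shared core have been measured so far. Compound 1 `CSc1ccccc1NC(=S)N1CCc2c(sc(NC(=O)c3ccccc3Cl)c2C(N)=O)C1` carries a 2-(methylsulfanyl)phenyl group on an amide-type nitrogen, and in a functional assay on MKN-74 cells (Homo sapiens) for antiproliferative activity, with a stated time of 24 h (on this read-out higher numbers stand for weaker inhibition and lower numbers for stronger inhibition), compound 1 gives 13800 nM. Compound 2 `COc1ccc(NC(=S)N2CCc3c(sc(NC(=O)c4ccccc4Cl)c3C(N)=O)C2)cc1` has a 4-methoxyphenyl group in that place, and in this assay compound 2 gives 19600 nM. Within the data shown here, the one measured step, a 1.4-fold higher number from compound 1 to compound 2 (0.15 log units; within the scatter), tells that exchanging one aromatic group for another on this nitrogen left the read-out essentially unchanged. Of the two numbers, that of compound 2 is the higher, but the gap to compound 1 is within the scatter, so no order between them can be claimed.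

Compound 3 `NC(=O)c1c(NC(=O)c2ccccc2Cl)sc2c1CCN(C(=S)Nc1cccnc1)C2` differs from compound 2 by pyridin-3-yl in place of 4-methoxyphenyl on an amide-type nitrogen. Among the measured compounds shown here, no measured compound carries a pyridin-3-yl group, so the only guide is the step from compound 1 to compound 2, which was within the scatter. On that basis the change to compound 3 is expected to produce no step beyond the scatter, a 1.1-fold higher number from compound 2 to compound 3 (0.05 log units; within the scatter). Compound 3 is therefore estimated at 22000 nM, within a range of 8000 nM to 60000 nM.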

Compound 3, half-maximal inhibitory concentration: 38600 nM
Beside the measured number, compound 3's estimate is 1.8-fold (0.24 log units) below it; the range from low to high includes it.
By their numbers in this assay, from the lowest: compounds 1, 2 and 3 (each within the scatter of the next, the first and the last beyond it).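

Among these compounds, the position on this thiourea nitrogen is not entirely indifferent to the aromatic group it carries: in this assay the data now hold a 2.8-fold higher number from compound 1 to compound 3 (0.45 log units; beyond the scatter) as the first step that passes the scatter, though only modestly. The other step with pyridin-3-yl entering, a 2.0-fold higher number from compound 2 to compound 3 (0.29 log units; within the scatter) in the same assay, stays inside the scatter, so exchanging 4-methoxyphenyl for pyridin-3-yl shows no clear effect, and compound 2 cannot be separated from either of the other two compounds. Only the two ends of this small series differ clearly, and nothing available explains that difference.

Going by these compounds, all three groups here are six-membered aromatic rings, so it remains open how a saturated ring such as cyclohexyl, or a simple chain such as ethyl, would read out on this nitrogen. On these data alone, it is also open whether moving the ring nitrogen, as in pyridin-2-yl or pyridin-4-yl, would give a different number from that of compound 3, and whether a morpholine-bearing phenyl group would fit the same range.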